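The source may report more compounds than this note shows. Statements on the series, on what has been measured and on what is new or still open speak of the compounds shown alone.

Going by the values given here, compound 1 `CCc1ccc(N2C(=O)C=CC2OCC(F)(F)F)cc1` is one of two compounds measured in a functional assay on A549 cells (Homo sapiens) for inhibition; a lower number here means a stronger inhibitor, a higher number a weaker inhibitor: compound 1 gives 8090 nM, and compound 2 `O=C1C=CC(OC(C(F)(F)F)C(F)(F)F)N1c1ccc(Cl)cc1` gives 4300 nM. Of these two numbers, that of compound 1 is the higher, but the gap to compound 2 lies within the usual scatter, so the two cannot be told apart.

Compound 3 `Cc1ccc(N2C(=O)C=CC2OCC(F)(F)F)cc1` differs from compound 1 in one place: hydrogen in place of methyl on a saturated chain carbon bound to an aromatic carbon. Among the compounds with values here, with no comparable step among the measured compounds, the expected step from compound 1 to compound 3 is a 1.1-fold higher number from compound 1 to compound 3 (0.05 log units; within the scatter), not clearly beyond the scatter in either direction. Compound 3 is therefore estimated at 9000 nM, in the range 3500 nM to 25000 nM.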

Compound 3, half-maximal inhibitory concentration: 13700 nM
Estimate against measurement, compound 3: 1.5-fold (0.18 log units) below; measured number inside the range.
By their numbers in this assay, from the lowest: compounds 2, 1 and 3 (each within the scatter of the next, the first and the last beyond it).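

In this assay, replacing ethyl with methyl gives a 1.7-fold higher number from compound 1 to compound 3 (0.23 log units; within the scatter) and so stays within the scatter, which means this first reading at the position shows no clear effect from removing one carbon of the chain. No outside measurement bears on this result.

Still open, going by these compounds, is whether a longer chain such as propyl, a branched group such as isopropyl, or an amine at this place would shift the number beyond the scatter. Also open, on these data alone, is how the bare hydrogen in place of ethyl would read.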